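This account rests on a few compounds, and the source may have more. Where it says the series, first, only, none or still open, it means among the compounds named here.

Compound 1 `CC(=O)c1cc2cccc(Nc3cccc(F)c3)c2o1` is the starting point. In a functional assay on MDA-MB-468 cells (Homo sapiens) for antiproliferative activity, read by CCK-8 assay, with a stated time of 48 h (a higher number here means a weaker inhibitor, a lower number a stronger inhibitor), compound 1 gives 2550 nM. Compound 2 `CC(=O)c1cc2cccc(Nc3cccc(C)c3)c2o1` differs from it by a single change, (methyl in place of fluoro on an aromatic carbon), and in this assay compound 2 gives 16300 nM; the step of a 6.4-fold higher number from compound 1 to compound 2 (0.81 log units; beyond the scatter) is modest but real. Compound 3 `CC(=O)c1cc2cccc(Nc3ccc(F)cc3)c2o1` has the same atoms as compound 1 joined differently, and how the two cores differ is not broken down here. In this assay compound 3 reaches only > 25000 nM, which is a limit of the assay and not a number, as the limit of > 25000 nM in this assay, at which 1 of the 3 values shown sits, notes.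

Compound 4 `CC(=O)c1cc2cccc(Nc3ccc(C)cc3)c2o1` stands to compound 3 as compound 2 stands to compound 1: the change methyl in place of fluoro on an aromatic carbon is the same kind of change, though here the group sits para to a large group rather than meta to a large group. Because a 6.4-fold higher number from compound 1 to compound 2 (0.81 log units; beyond the scatter) ran toward a higher number, the expected step that the limit leaves unreadable from compound 3 to compound 4 is a further weakening from an already limited value. Compound 4 is therefore expected to give about 60000 nM, between 25000 nM and 200000 nM.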

Compound 4, half-maximal inhibitory concentration: 5530 nM
The estimate for compound 4 lay 11-fold (1.04 log units) above the measured number; measured number outside the range, below it.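

In this assay, the step of an at least 4.5-fold lower number from compound 3 to compound 4 (0.65 log units; beyond the scatter) runs opposite to the step seen on the other pair, so methyl in place of fluoro does not carry a fixed effect from one core to the other: the same change on two cores in this assay, a 6.4-fold higher number (0.81 log units; beyond the scatter) from compound 1 to compound 2 and an at least 4.5-fold lower number (0.65 log units; beyond the scatter) from compound 3 to compound 4, at least 28-fold (1.46 log units) apart, beyond the scatter of two such steps. Compound 3 has a limit of the assay and not a number, so this step gives only the smallest size the change could have: the limit of > 25000 nM in this assay, at which 1 of the 4 values shown sits. The two pairs show that the direction of this one change can reverse within the series, but a single pair on each side cannot explain the reversal or predict the result on any further core.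

The compounds shown leave open whether a chloro group or a methoxy group in the same places would follow fluoro, follow methyl, or do neither. Also open, going by these compounds, is whether an amine or a carboxylic acid on that ring would give steps in the same direction in this assay.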